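From a tert-butyl amide to a 4-methylbenzyl amide

The source may hold more compounds than are shown below. What is called first, only, known or untested is meant among the compounds shown, and "the series" means these compounds.

Two amides share one core. Compound 1 `C=CC1=C(C(=O)NC(C)(C)C)C(c2ccc(OC)cc2)OC1` reaches only the ceiling of a functional assay on QGY7701 cells (Homo sapiens) for cytotoxicity, read by MTT assay, with a stated time of 24 h; on this read-out higher numbers stand for weaker inhibition and lower numbers for stronger inhibition: compound 1 gives > 100000 nM, which is a limit rather than a number. Compound 2 `C=CC1=C(C(=O)NCCC)C(c2ccc(OC)c(OC)c2)OC1` likewise stops at a limit, giving > 100000 nM in this assay. Both measurements sit at the limit of > 100000 nM in this assay, at which 2 of the 2 values shown sit, so compound 1 stands at that limit with no number to rank it. Compound 3 `C=CC1=C(C(=O)NCc2ccc(C)cc2)C(c2ccc(OC)cc2)OC1` carries 4-methylbenzyl in place of tert-butyl on an amide-type nitrogen. Going by the values given here, with no measured step to guide it, no movement beyond the usual scatter is expected for a number no higher from compound 1 to compound 3 (the limit leaves the size open). Compound 3 is thus estimated at 100000 nM, within 30000 nM to 300000 nM, most likely again a limit.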

Compound 3, half-maximal inhibitory concentration: 43100 nM
Compound 3: the middle estimate sits 2.3-fold (0.37 log units) above what was measured; the measured number falls inside the stated range.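

In this assay, the amide-type nitrogen proves to be a place where a single change can move the read-out: 4-methylbenzyl in place of tert-butyl gives an at least 2.3-fold lower number from compound 1 to compound 3 (0.36 log units; beyond the scatter). Compound 3 is the only one of the three compounds with a number rather than a limit, so this step has a lower bound but no fixed size: the limit of > 100000 nM in this assay, at which 2 of the 3 values shown sit.

The compounds shown leave open whether the six-membered aromatic ring or its methyl group accounts for the step. A plain benzyl group, a phenethyl group or a longer chain on this nitrogen could separate the two.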